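Replacing a dimethylaminophenyl group with a thiophene ring

The compounds below may be only part of what the source reports. "The series", "measured", "known", "first", "only" and "open" are said of these compounds alone.

Among the measured compounds shown here, in a functional assay on MCF7 cells (Homo sapiens) for cytotoxicity, read by sulforhodamine B assay, with a stated time of 48 h (on this read-out lower numbers stand for stronger inhibition and higher numbers for weaker inhibition), compound 2 `CC(=O)OC[C@H]1O[C@@H](n2cc(CN3C(=O)/C(=C/c4ccc(N(C)C)cc4)c4ccccc43)nn2)[C@H](OC(C)=O)[C@@H](OC(C)=O)[C@@H]1OC(C)=O` gives 25200 nM, the only definite number among the values shown. Compound 1 `CC(=O)OC[C@H]1O[C@@H](n2cc(CN3C(=O)/C(=C/c4ccc(C)cc4)c4ccccc43)nn2)[C@H](OC(C)=O)[C@@H](OC(C)=O)[C@@H]1OC(C)=O` reaches only the assay limit of > 100000 nM in this assay. For the measured compounds named here, the whole measured picture is thus set by the limit of > 100000 nM in this assay, at which 1 of the 2 values shown sits, and by the single step of an at least 3.9-fold lower number from compound 1 to compound 2 (0.59 log units; beyond the scatter). Compound 3 `CC(=O)OC[C@H]1O[C@@H](n2cc(CN3C(=O)/C(=C/c4cccs4)c4ccccc43)nn2)[C@H](OC(C)=O)[C@@H](OC(C)=O)[C@@H]1OC(C)=O` differs from compound 2 by thiophen-2-yl in place of 4-(dimethylamino)phenyl on a double-bonded chain carbon bound to a double-bonded ring carbon, which removes the dimethylamino group that marked that step. Given an at least 3.9-fold lower number from compound 1 to compound 2 (0.59 log units; beyond the scatter), compound 3 is expected to move by a 2.4-fold higher number from compound 2 to compound 3 (0.38 log units; beyond the scatter), an estimated 60000 nM in this assay, between 20000 nM and 200000 nM.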

Compound 3, half-maximal inhibitory concentration: 28100 nM
For compound 3 the middle estimate is 2.1-fold (0.33 log units) above the measured one; measured number inside the range.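

The dimethylamino group that marked the earlier step turns out not to be required on the double-bonded chain carbon: thiophen-2-yl in place of 4-(dimethylamino)phenyl gives a 1.1-fold higher number from compound 2 to compound 3 (0.05 log units; within the scatter). The smaller five-membered ring also separates from 4-methylphenyl, with an at least 3.5-fold lower number from compound 1 to compound 3 (0.55 log units; beyond the scatter). Compound 1 stands at a limit, not at a number: the limit of > 100000 nM in this assay, at which 1 of the 3 values shown sits.

From the compounds shown here alone, whether any aromatic ring is needed here remains open. So does the effect of a simple amine or a carboxylic acid on the phenyl ring at this place.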